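Cytotoxicity notes on a boron-containing chalcone series

The source may hold more compounds than are shown below. What is called first, only, known or untested is meant among the compounds shown, and "the series" means these compounds.

Measured so far:
compound 1, `COc1ccccc1C(=O)/C=C/c1ccc2c(c1)B(O)OC2`, 6.35 ug/mL in an ADME assay on L929 cells (Mus musculus) for cytotoxicity, read by resazurin assay, with a stated time of 72 h; a lower number here means a stronger inhibitor, a higher number a weaker inhibitor
compound 2, `COCOc1ccccc1C(=O)/C=C/c1ccc2c(c1)B(O)OC2`, 9.02 ug/mL
compound 3, `O=C(/C=C/c1ccc2c(c1)B(O)OC2)c1ccccc1F`; for compound 3 the result is a limit of the assay, > 10 ug/mL

The three values sit close together. The step of a 1.4-fold higher number from compound 1 to compound 2 (0.15 log units; within the scatter) is within the scatter. Among the measured compounds shown here, the step of an at least 1.5-fold higher number from compound 1 to compound 3 (0.19 log units; that floor lies within the scatter) and the step of an at least 1.1-fold higher number from compound 2 to compound 3 (0.04 log units; that floor lies within the scatter) both rest on the limit for compound 3 and tell only that its number is at the limit or beyond; the limit of > 10 ug/mL in this assay, at which 1 of the 3 values shown sits, marks where it stands. Nothing in the measured steps separates the three compounds.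

Compound 4, `O=C(/C=C/c1ccc2c(c1)B(O)OC2)c1cccc(O)c1`, is the next unmeasured member. The change from compound 3 is 3-hydroxyphenyl in place of 2-fluorophenyl on a carbonyl carbon. For the measured compounds named here, no measured step swaps a fluoro for a hydroxy group or moves a substituent on that ring, so none bears directly on this change; the only guide is that every measured step so far is within the scatter and that compound 3 is already at the limit. A step of about an at least 1.1-fold lower number from compound 3 to compound 4 (0.04 log units; that floor lies within the scatter) is therefore expected, which is to say no step beyond the scatter. Compound 4 is estimated at 9 ug/mL in this assay, with a range from 4 ug/mL to 20 ug/mL, and a fair chance that the assay again reports only a limit.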

Compound 4, half-maximal inhibitory concentration: 7.56 ug/mL
The estimate for compound 4 lay 1.2-fold (0.08 log units) above the measured number; low and high end bracket the measured number.
By their numbers in this assay, from the lowest: compounds 1, 4 and 2 (each within the scatter of the next). At a limit, above all of these: compound 3.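

In this assay, compound 4 shows that a 3-hydroxyphenyl group on this carbonyl carbon gives a measured number, so the series now has a reading for a ring with a hydrogen-bond donor at this place. On these data alone, the change to this group gives an at least 1.3-fold lower number from compound 3 to compound 4 (0.12 log units; that floor lies within the scatter), so the floor of the step does not establish a difference beyond the scatter, and its true size stays unknown. Compound 3 remains a limit of the assay: the limit of > 10 ug/mL in this assay, at which 1 of the 4 values shown sits.

The exchange alters both the substituent and its place on the ring, and the compounds shown do not separate these two changes. Also open, as far as these compounds go, is how this assay responds when an amine or a carboxylic acid replaces the hydroxy group on that ring.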